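This account rests on a few compounds, and the source may have more. Where it says the series, first, only, none or still open, it means among the compounds named here.

Compound 1 `Cn1c(N)c(-c2nc3ccccc3[nH]2)c2nc(C#N)c(C#N)nc21`: > 50000 nM
Compound 2 `CN(C)CCn1c(N)c(-c2nc3ccccc3[nH]2)c2nc(C#N)c(C#N)nc21`: 3780 nM
Compound 3 `CN(C)CCCn1c(N)c(-c2nc3ccccc3[nH]2)c2nc(C#N)c(C#N)nc21`: 2390 nM

In a functional assay on HL60/MX2 cells (Homo sapiens) for antiproliferative activity, read by MTT assay, with a stated time of 48 h (on this read-out higher numbers stand for weaker inhibition and lower numbers for stronger inhibition), compound 1 gives only a limit, > 50000 nM, so where it stands is known just as the limit of > 50000 nM in this assay, at which 1 of the 3 values shown sits. Compound 4 `N#Cc1nc2c(-c3nc4ccccc4[nH]3)c(N)n(CCCO)c2nc1C#N` differs from compound 1 by 2-hydroxyethyl in place of hydrogen on a saturated chain carbon bound to an aromatic nitrogen. The measured steps that bear on this change place a different group at the same position: an at least 13-fold lower number from compound 1 to compound 2 (1.12 log units; beyond the scatter) and an at least 20-fold lower number from compound 1 to compound 3 (1.32 log units; beyond the scatter), both large gains. Between those two amine chains, a 1.6-fold lower number from compound 2 to compound 3 (0.20 log units; within the scatter), which lies within the scatter. The group entering in compound 4 carries a hydroxyl rather than a dimethylamino, so the amine steps give only a loose guide; some gain is expected, though smaller and less certain. Compound 4 is therefore estimated at 15000 nM, between 3000 nM and 60000 nM, meaning an expected at least 3.3-fold lower number from compound 1 to compound 4 (0.52 log units; beyond the scatter).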

Compound 4, half-maximal inhibitory concentration: > 50000 nM
Compound 4 gave a limit, no number; the forecaster's own chance of this, stated with the estimate: 35%; middle value at least 3.3-fold (0.52 log units) away from the limit.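

In this assay compound 4 gives > 50000 nM, which is a limit of the assay. Replacing the dimethylamino group with a hydroxyl costs a large part of the activity, with an at least 20-fold higher number from compound 3 to compound 4 (1.32 log units; beyond the scatter) and an at least 13-fold higher number from compound 2 to compound 4 (1.12 log units; beyond the scatter). A chain on the aromatic nitrogen is therefore not enough in itself: among these compounds, the gain appears only with the dimethylamino end.

The step from compound 1 to compound 4 cannot be read, since both values are limits: the limit of > 50000 nM in this assay, at which 2 of the 4 values shown sit. On these data alone, whether a primary amine or a carboxylic acid at the chain end would restore the activity remains open.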